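The source may hold more compounds than are shown below. What is called first, only, known or untested is meant among the compounds shown, and "the series" means these compounds.

Measured in a functional assay on LNCaP cells (Homo sapiens) for cytotoxicity, read by MTT assay, with a stated time of 72 h; a higher number here means a weaker inhibitor, a lower number a stronger inhibitor:

- compound 1, `N[C@H]1CC[C@H](Nc2c(C(=O)NCc3ccc(F)cc3)nc(N3CCCCS3(=O)=O)c3cccnc23)CC1`, gives 8000 nM
- compound 2, `Nc1cccc(Nc2c(C(=O)NCc3ccc(F)cc3)nc(Br)c3cccnc23)c1`, gives 8000 nM
- compound 3, `Nc1ccc(Nc2c(C(=O)NCc3ccc(F)cc3)nc(Br)c3cccnc23)cc1`, gives 7000 nM

Compound 2 stands level with compound 1 at the digits recorded, the two together the highest of the three numbers; compound 3 lies a short way off, a 1.1-fold lower number from compound 2 to compound 3 (0.06 log units; within the scatter), which is within the scatter. Nothing among the three measured compounds therefore separates from the others beyond the usual repeat-to-repeat spread.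

Compound 4, `CN(C)CCCNc1c(C(=O)NCc2ccc(F)cc2)nc(Br)c2cccnc12`, differs from compound 2 in one place: 3-(dimethylamino)propyl in place of 3-aminophenyl on a nitrogen on an aromatic ring. Going by the values given here, the one measured step in the set, from compound 2 to compound 3, swaps 4-aminophenyl for 3-aminophenyl and stays within the scatter; it does not exchange a ring for a chain, so it bears on the change to compound 4 only as a sign that variation at this nitrogen has so far moved nothing. Among the compounds with values here, no measured pair covers a group with no ring at this position. On that basis compound 4 is expected to sit near compound 2, no change at the digits printed from compound 2 to compound 4 (within the scatter), with the range widened for the untested kind of change. The estimate for compound 4 in this assay is 8000 nM, between 2500 nM and 25000 nM.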

Compound 4, half-maximal inhibitory concentration: 8000 nM
Compound 4: middle estimate and measured number agree at the digits printed, within the range that was stated.
By their numbers in this assay, from the lowest: compounds 3, 1, 2 and 4 (each within the scatter of the next).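

Before compound 4, variation on this nitrogen covered only 3-aminophenyl and 4-aminophenyl; 3-(dimethylamino)propyl, which has no ring, now gives a number in this assay that does not separate from either aromatic partner (no change at the digits printed from compound 2 to compound 4 (within the scatter) and a 1.1-fold higher number from compound 3 to compound 4 (0.06 log units; within the scatter)). Within these three compounds, then, neither the six-membered aromatic ring nor the hydrogen-bond donor counted on 3-aminophenyl is needed for a number at this level. No supporting data are available to explain this lack of separation.

As far as these compounds go, whether any group on this nitrogen can move the number beyond the scatter remains open. A carboxylic acid or a longer chain ending in a primary amine at this position would test that, as the compounds shown include neither.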